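The source may hold more compounds than are shown below. What is called first, only, known or untested is meant among the compounds shown, and "the series" means these compounds.

Working notes on the series. Compound 1 `OC1CCN(c2nccnc2OC2CN(c3ccc4ccccc4n3)C2)CC1`, compound 2 `COCC1CCN(c2nccnc2OC2CN(c3ccc4ccccc4n3)C2)CC1` and compound 3 `NC(=O)C1CCN(c2nccnc2OC2CN(c3ccc4ccccc4n3)C2)CC1` share a core and differ on a saturated ring carbon. In a physicochemical assay for solubility, in phosphate buffer, at pH 7.4 (on this read-out higher numbers stand for higher solubility and lower numbers for lower solubility), compound 1 gives 99000 nM and compound 2 gives 53000 nM while compound 3 gives 14000 nM as the lowest of the three numbers. The steps measured so far are a 1.9-fold lower number from compound 1 to compound 2 (0.27 log units; within the scatter) and a 7.1-fold lower number from compound 1 to compound 3 (0.85 log units; beyond the scatter) and a 3.8-fold lower number from compound 2 to compound 3 (0.58 log units; beyond the scatter) and all of them sit on that saturated ring carbon.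

Compound 4 `Cc1ccc(-c2nccnc2OC2CN(c3ccc4ccccc4n3)C2)cc1` has not been measured. It carries 4-methylphenyl in place of 4-carbamoylpiperidin-1-yl on an aromatic carbon is the full count of the difference. Going by the values given here, no measured step replaces the whole group, so the three steps give only a rough scale, and the direction is a judgement from the structural change alone. In this assay the expected step is a 14-fold lower number from compound 3 to compound 4 (1.15 log units; beyond the scatter) as an estimate with wide uncertainty. Compound 4 is expected at 1000 nM within an estimated range from 100 nM to 7000 nM for now.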

Compound 4, solubility: < 1000 nM
Compound 4 ended at the assay's limit; the forecaster's own chance of this, stated with the estimate: 15%; the middle value lies on the limit itself.
By their numbers in this assay, from the lowest: compound 3; then compounds 2 and 1 (each within the scatter of the next). At a limit, below all of these: compound 4.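

Exchanging the whole group on this aromatic carbon moves the read-out in this assay much further than anything seen so far, with an at least 14-fold lower number from compound 3 to compound 4 (1.14 log units; beyond the scatter), an at least 53-fold lower number from compound 2 to compound 4 (1.72 log units; beyond the scatter) and an at least 99-fold lower number from compound 1 to compound 4 (1.99 log units; beyond the scatter). Going by these compounds alone, the changes on the saturated ring carbon reached no further than a 7.1-fold lower number from compound 1 to compound 3 (0.85 log units; beyond the scatter), so this position is the first to take the series down to the floor of the assay. Compound 4 stands at a limit and not at a number, so each of these steps gives only a minimum size: the limit of < 1000 nM in this assay, at which 1 of the 4 values shown sits.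

The compounds shown leave open whether the fall follows the loss of the piperidine ring or the entry of the 4-methylphenyl group. A phenyl ring carrying an amine or a carboxylic acid in place of the methyl would separate the two.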